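The compounds below may be only part of what the source reports. "The series", "measured", "known", "first", "only" and "open" are said of these compounds alone.

Series of ureas on a shared core. Compound 1 `C=CCN(CC)S(=O)(=O)NC(=O)Nc1c(C(C)C)cccc1C(C)C` gives 2100 nM in an assay on liver for inhibition of sterol O-acyltransferase 1 (Rattus norvegicus), using microsomes; a higher number here means a weaker inhibitor, a lower number a stronger inhibitor. Going by the values given here, compound 2 `CCCCCCNS(=O)(=O)NC(=O)Nc1c(C(C)C)cccc1C(C)C` gives 8100 nM in this assay, the higher of the two numbers; the only recorded step is a 3.9-fold higher number from compound 1 to compound 2 (0.59 log units; beyond the scatter). Compound 3 `CCCCCCN(CCCCCC)S(=O)(=O)NC(=O)Nc1c(C(C)C)cccc1C(C)C` differs from compound 2 by hexyl in place of hydrogen on a sulfonamide nitrogen. Among the compounds with values here, no measured step isolates this change, as the recorded step mixes an exchange of groups with the hydrogen present on that nitrogen in compound 2 only, so it bears on it only loosely. A modest move toward a lower number is expected for compound 3, a 2.0-fold lower number from compound 2 to compound 3 (0.31 log units; beyond the scatter), giving an estimate of 4000 nM with a range from 1500 nM to 11000 nM.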

Compound 3, half-maximal inhibitory concentration: 510 nM
For compound 3 the middle estimate is 7.8-fold (0.89 log units) above the measured one, outside the stated range (below it).
By their numbers in this assay, from the lowest: compound 3; then compound 1; then compound 2.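

Going by these compounds alone, replacing hydrogen with hexyl on the sulfonamide nitrogen gives a 16-fold lower number from compound 2 to compound 3 (1.20 log units; beyond the scatter) in this assay and is the first step to isolate the loss of that hydrogen. With one hexyl held constant, this position therefore responds strongly to a second hexyl. Nothing available explains the size of this step.

Still open, from the compounds shown here alone, is whether a shorter chain such as butyl on this nitrogen would give a similar number. Going by these compounds, the effect of a second chain ending in an amine or a carboxylic acid also remains open.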